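Ethylcarbamoyl in place of carbamoyl: expected effect on compound 4

This account rests on a few compounds, and the source may have more. Where it says the series, first, only, none or still open, it means among the compounds named here.

The series is read in a functional assay on SMMC-7721 cells (Homo sapiens) for cytotoxicity, read by MTT assay, with a stated time of 72 h; a lower number here means a stronger inhibitor, a higher number a weaker inhibitor. Compound 1 `Cc1ccc(Cn2cc(CSC(=S)N3CCN(C(N)=O)CC3)nn2)cc1` sits at the assay limit there, giving > 128000 nM. Compound 2 `CCNC(=O)N1CCN(C(=S)SCc2cn(Cc3ccc(C)cc3)nn2)CC1` is likewise reported only as a limit, > 128000 nM. Compound 3 `COc1ccc(Cn2cc(CSC(=S)N3CCN(C(N)=O)CC3)nn2)cc1` also reaches only the limit, > 128000 nM. The change from compound 1 to compound 2 is ethyl in place of hydrogen on an amide-type nitrogen; its step is a step that the two limits leave unreadable from compound 1 to compound 2, because all three values sit at the same limit (the limit of > 128000 nM in this assay, at which 3 of the 3 values shown sit). Compound 3 differs from compound 1 in its core by methoxy in place of methyl on an aromatic carbon, with the step that the two limits leave unreadable from compound 1 to compound 3. Compound 4 `CCNC(=O)N1CCN(C(=S)SCc2cn(Cc3ccc(OC)cc3)nn2)CC1` is not yet measured; it carries the same change as from compound 1 to compound 2, (ethyl in place of hydrogen on an amide-type nitrogen), on the core of compound 3, and the place is the same. The step from compound 3 to compound 4 is expected to be a step that the limit leaves unreadable from compound 3 to compound 4, which rests on compound 1 and compound 2 both being reported only as a limit (the limit of > 128000 nM in this assay, at which 3 of the 3 values shown sit). For compound 4 the estimate in this assay is 200000 nM, most likely again reported as a limit, within 128000 nM to 600000 nM.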

Compound 4, half-maximal inhibitory concentration: > 128000 nM
Compound 4: only a limit was reported; the forecaster's own chance of this, stated with the estimate: 85%; the middle value does not contradict the limit.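

No new step can be read from compound 3 to compound 4 or from compound 2 to compound 4, because compound 1, compound 2, compound 3 and compound 4 all stand at one limit: the limit of > 128000 nM in this assay, at which 4 of the 4 values shown sit.

The compounds shown leave open whether ethyl in place of hydrogen on the amide-type nitrogen, or methoxy in place of methyl, changes activity at all.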